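Cyclopropyl for 3-fluorophenyl on the tetrazole-bearing amide

A few compounds are considered here, and "the series" means these few. Any claim that something is new, unique, unknown or untested is made for them only; others in the source may bear on it.

Measured compounds:
compound 1, `Cc1cc(NC(=S)Cn2nnc(-c3ccccc3)n2)n(C2CCCCC2)n1`: 80%
compound 2, `O=C(Cn1nnc(-c2ccccc2)n1)Nc1ccccn1`: "not active" (no number reported)
compound 3, `Cc1cc(NC(=O)Cn2nnc(-c3cccc(F)c3)n2)n(C2CCCCC2)n1`: 96%

In an assay on HEK293 cells for activation of Kir3.1/Kir3.2 (Homo sapiens), read by thallium flux (on this read-out lower numbers stand for smaller maximal responses and higher numbers for larger maximal responses), compound 3 gives 96%, the highest of the two numbers reported. Compound 1 gives 80% in this assay, a number beyond the scatter below that of compound 3; compound 1 and compound 3 differ in more than one place, so the two values are only set side by side. Compound 2 is recorded as "not active" (no number reported) in this assay, without a number.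

Compound 4, `Cc1cc(NC(=O)Cn2nnc(C3CC3)n2)n(C2CCCCC2)n1`, differs from compound 3 in one place: cyclopropyl in place of 3-fluorophenyl on an aromatic carbon. Within the data shown here, no measured pair shows this exchange, so its size is unknown from the data. Both compounds with a number, compound 1 and compound 3, carry a six-membered aromatic ring at this position; compound 4 does not. The step from compound 3 to compound 4 is expected to be downward and beyond the scatter, a number 36 percentage points lower from compound 3 to compound 4 (beyond the scatter). Compound 4 is expected to give about 60%, in the range 30% to 90%.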

Compound 4, largest response reached (Emax), in percent of the reference or control that the assay uses: > 68%
Compound 4 ended at the assay's limit; the forecaster's own chance of this, stated with the estimate: 20%; middle value at least 8 percentage points from the limit.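

No step can be read from compound 3 to compound 4, since the value of compound 4 is a limit of the assay and not a number: the limit of > 68% in this assay, at which 1 of the 4 values shown sits.

The compounds shown leave open how far cyclopropyl in place of 3-fluorophenyl on the shared core changes the maximal response, and in which direction.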